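Clearance notes: benzoyl in place of ethoxycarbonyl

The compounds below may be only part of what the source reports. "The series", "measured", "known", "first", "only" and "open" are said of these compounds alone.

Compound 1 `CCOC(=O)c1ccccc1CC[C@H](SC[C@@H](C)C(=O)O)c1cccc(/C=C/c2ccc3ccc(Cl)cc3n2)c1` has been run in an in vivo ADME assay on the whole organism (plasma) for pharmacokinetics, with Rattus norvegicus as the target, at a dose of 5 mg/kg by the intravenous route (on this read-out higher numbers stand for fast clearance and lower numbers for slow clearance), and gives 4.8 mL/min/kg. Compound 2 `COC(=O)c1cccc(CC[C@H](SC[C@@H](C)C(=O)O)c2cccc(/C=C/c3ccc4ccc(Cl)cc4n3)c2)c1` gives 6 mL/min/kg in this assay. Of these two numbers compound 1 is the lowest, with compound 2 nearest; the step of a 1.3-fold higher number from compound 1 to compound 2 (0.10 log units; within the scatter) lies within the scatter, so no order between the two is claimed.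

Compound 3 `C[C@H](CS[C@@H](CCc1ccccc1C(=O)c1ccccc1)c1cccc(/C=C/c2ccc3ccc(Cl)cc3n2)c1)C(=O)O` is still to be measured. It differs from compound 1 in one place: phenyl in place of ethoxy on a carbonyl carbon. The same difference, cut one bond further out, reads ethoxycarbonyl to benzoyl. For the measured compounds named here, the only measured step, a 1.3-fold higher number from compound 1 to compound 2 (0.10 log units; within the scatter), reworks the ester by putting 3-(methoxycarbonyl)phenyl in place of 2-(ethoxycarbonyl)phenyl and stays within the scatter. Going by the values given here, no measured pair exchanges the ester for a ketone, so no step bears directly on the change to compound 3. The expected step of a 1.3-fold higher number from compound 1 to compound 3 (0.10 log units; within the scatter) is therefore one of no size beyond the scatter, in no set direction, and the range is set wide.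

Compound 3 is expected to give 6 mL/min/kg in this assay, with a range from 2.5 mL/min/kg to 14 mL/min/kg.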

Compound 3, clearance: 18 mL/min/kg
Beside the measured number, compound 3's estimate is 3.0-fold (0.48 log units) below it; measured number above the stated range.
By their numbers in this assay, from the lowest: compounds 1 and 2 (each within the scatter of the next); then compound 3.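

In this assay, for the compounds shown here, phenyl in place of ethoxy on a carbonyl carbon gives a 3.8-fold higher number from compound 1 to compound 3 (0.57 log units; beyond the scatter), the first step to lie beyond the scatter, whereas the reworked ester gives a 1.3-fold higher number from compound 1 to compound 2 (0.10 log units; within the scatter). What sits on this carbonyl carbon therefore matters to the read-out: going from ethoxycarbonyl to benzoyl moves the number towards faster clearance, a modest step, while the two esters, compound 1 and compound 2, remain indistinguishable. Nothing at hand accounts for the rise.

This single step removes the ethoxy group and brings in an aromatic ring in one move, so the two contributions remain unseparated; a methyl or a dimethylamino group on the same carbonyl carbon would begin to pull them apart. Also open, on these data alone, is whether the benzoyl step carries over to the arrangement of compound 2, which a 3-benzoylphenyl group on the same saturated chain carbon would test, and whether a phenyl ring with a fluorine atom or a methoxy group on the ketone would shift the number further.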